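From 4-chlorophenyl to 4-iodophenyl in a small series

This account rests on a few compounds, and the source may have more. Where it says the series, first, only, none or still open, it means among the compounds named here.

Values in a functional assay on SK-MEL-28 cells (Homo sapiens) for cytotoxicity, read by CCK-8 assay, with a stated time of 24 h (on this read-out higher numbers stand for weaker inhibition and lower numbers for stronger inhibition), for the three measured compounds:
compound 1 `COc1ccccc1Oc1c(N)nc(-c2ccccc2)nc1Cl` gives 3140 nM
compound 2 `COc1ccccc1Oc1c(N)nc(-c2cccc(Cl)c2)nc1Cl` gives 19400 nM
compound 3 `COc1ccccc1Oc1c(N)nc(-c2ccc(Cl)cc2)nc1Cl` gives 120 nM

Compound 3 has the lowest number of the three, and its gaps to both others lie beyond the scatter, so it is the strongest so far. Compound 4 `COc1ccccc1Oc1c(N)nc(-c2ccc(I)cc2)nc1Cl` has not been measured yet. It carries iodo in place of chloro on an aromatic carbon and keeps the shared core unchanged. The new atom sits on a six-membered aromatic ring of carbon only, para to a large group.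

Among the measured compounds shown here, three measured steps bear on this change. Adding chloro gave a large gain in one case a 26-fold lower number from compound 1 to compound 3 (1.42 log units; beyond the scatter) and a modest loss in the other 6.2-fold higher number from compound 1 to compound 2 (0.79 log units; beyond the scatter). Going from 3-chlorophenyl to 4-chlorophenyl gave another large step a 160-fold lower number from compound 2 to compound 3 (2.21 log units; beyond the scatter). Where the chloro sits therefore matters greatly in these three compounds. For the measured compounds named here, compound 4 keeps its halogen in the favourable place, but no measured step swaps one halogen for another. The expectation in this assay is thus no step beyond the scatter, with a slight lean upward, since compound 3 (120 nM) is the lowest value seen. The estimated change is a 1.7-fold higher number from compound 3 to compound 4 (0.22 log units; within the scatter) (an expectation only). Compound 4 is expected at 200 nM (estimated range 40 nM to 1000 nM).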

Compound 4, half-maximal inhibitory concentration: 1250 nM
Compound 4: the middle estimate sits 6.3-fold (0.80 log units) below what was measured; measured number above the stated range.
By their numbers in this assay, from the lowest: compound 3; then compound 4; then compound 1; then compound 2.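

In this assay, the identity of the halogen on this aromatic carbon matters as well as where it sits: with the place kept the same, iodo in place of chloro gives a large loss, a 10-fold higher number from compound 3 to compound 4 (1.02 log units; beyond the scatter). Iodo still gives a better result than hydrogen at this place, a 2.5-fold lower number from compound 1 to compound 4 (0.40 log units; beyond the scatter), but this modest gain is much smaller than the large one seen with chloro, a 26-fold lower number from compound 1 to compound 3 (1.42 log units; beyond the scatter). The 4-iodophenyl group also remains well ahead of the 3-chlorophenyl group, a 16-fold lower number from compound 2 to compound 4 (1.19 log units; beyond the scatter), so among these compounds, a halogen at this place gives lower numbers than hydrogen, while the one compound with chloro on a different ring carbon, compound 2, goes against any simple benefit from adding a halogen.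

Nothing in the data shown explains why chloro and iodo differ so much here. As far as these compounds go, whether fluoro, bromo or a methyl group at this same place would give a number closer to that of compound 3 or compound 4 remains open.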